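Methoxy step from compound 3 to compound 4

The compounds below may be only part of what the source reports. "The series", "measured", "known", "first", "only" and "open" are said of these compounds alone.

Measured in an ADME assay on HEK293 cells (Homo sapiens) for cytotoxicity, read by ATP content, with a stated time of 6 h (a lower number here means that less compound is tolerated, a higher number that more compound is tolerated), all values limits:
Compound 1 `CCCCNc1nc(N)nc2ccn(Cc3ccccn3)c12` gives > 24000 nM
Compound 2 `CCCCNc1nc(N)nc2ccn(Cc3ncccc3OC)c12` gives > 24000 nM
Compound 3 `Cc1cnc(COc2nc(N)nc3ccn(Cc4ccccn4)c23)o1` gives > 24000 nM

Compound 3 stands at > 24000 nM, which is a limit and not a number. All the measured compounds share this position: the limit of > 24000 nM in this assay, at which 3 of the 3 values shown sit. Compound 4 `COc1cccnc1Cn1ccc2nc(N)nc(OCc3ncc(C)o3)c21` carries one change from compound 3: methoxy in place of hydrogen on an aromatic carbon. The same exchange, methoxy in place of hydrogen on an aromatic carbon, appears as a step that the two limits leave unreadable from compound 1 to compound 2. The other measured change is a step that the two limits leave unreadable from compound 1 to compound 3. Neither gives a size to carry over, so no direction is expected in this assay, and the expected outcome is a step that the limit leaves unreadable from compound 3 to compound 4. The estimate for compound 4 is 30000 nM, with an expected range from 15000 nM to 60000 nM.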

Compound 4, half-maximal cytotoxic concentration: > 24000 nM
Compound 4: no number, only a limit; the forecaster's own chance of this, stated with the estimate: 90%; the middle value lies beyond the limit too.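

In this assay compound 4 gives > 24000 nM as a limit and not a number, so neither the step to it from compound 3 nor that from compound 2 can be read. The compounds shown leave open whether either exchange changes this read-out at all.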